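A few compounds are considered here, and "the series" means these few. Any claim that something is new, unique, unknown or untested is made for them only; others in the source may bear on it.

Series notes, a functional assay on A2780 cells (Homo sapiens) for antiproliferative activity; on this read-out lower numbers stand for stronger inhibition and higher numbers for weaker inhibition:

- compound 1 `CN(C)C(=O)N1Cc2ccccc2C(c2cccc(O)c2)C1`: "not determined" (no result reported)
- compound 2 `CN(C)C(=O)N1Cc2cc(F)ccc2C(c2cccc(O)c2)C1`: "not determined" (no result reported)
- compound 3 `CN(C)C(=O)N1Cc2cc(Cl)ccc2C(c2cccc(O)c2)C1`: 1190 nM

For the measured compounds named here, compound 3 is thus the only member of the series with a number in this assay; compounds 1 and 2 give nothing to set it against, so no measured step between compounds exists and compound 3 stands alone as the reference point. Compound 4 `CN(C)C(=O)N1Cc2cc(I)ccc2C(c2cccc(O)c2)C1` is not yet measured; it differs from compound 3 by iodo in place of chloro on an aromatic carbon. Going by the values given here, with no step in the data to anchor the size of such a change, only a modest shift is expected in this assay, in either direction, most likely not beyond the usual scatter. Compound 4 is therefore estimated at 900 nM, with a range from 300 nM to 3000 nM. The expected step is then a 1.3-fold lower number from compound 3 to compound 4 (0.12 log units; within the scatter).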

Compound 4, half-maximal inhibitory concentration: 363 nM
Beside the measured number, compound 4's estimate is 2.5-fold (0.39 log units) above it; measured number inside the range.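

In this assay, for the compounds shown here, iodo in place of chloro on this aromatic carbon, meta to a fused ring and para to a fused ring, gives a 3.3-fold lower number from compound 3 to compound 4 (0.52 log units; beyond the scatter) and so provides the first measured evidence that activity responds to the halogen here. Steps involving compound 1 and compound 2 cannot be read, so the effect of either halogen relative to hydrogen or fluoro remains unknown. No evidence bearing on the cause of this step is available. Still open, on these data alone, is whether bromo would fall within this halogen step, and whether an amine or a carboxylic acid at the same carbon would retain activity.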